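The compounds below may be only part of what the source reports. "The series", "measured", "known", "first", "only" and "open" are said of these compounds alone.

Four compounds share one core and are compared in a functional assay on DU-145 cells (Homo sapiens) for cytotoxicity, read by CCK-8 assay and cell counting, with a stated time of 2 days; on this read-out lower numbers stand for stronger inhibition and higher numbers for weaker inhibition. Compound 1 `Oc1cccc(-c2cc(-c3cccc(Cl)c3)nc(-c3ccco3)c2)c1` gives 2020 nM in this assay. Compound 2 `Oc1ccc(-c2cc(-c3cccnc3)nc(-c3cccc(Cl)c3)c2)cc1`, which carries a pyridin-3-yl group and a 4-hydroxyphenyl group, gives 22900 nM in this assay. Compound 3 `Oc1ccc(-c2cc(-c3ccncc3)nc(-c3cccc(Cl)c3)c2)cc1` was tested but the entry for compound 3 in this assay reads "not determined" (no result reported), so compound 3 stands without a value of its own and offers no anchor for the next step.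

Compound 4 `Oc1ccc(-c2cc(-c3cccc(Cl)c3)nc(-c3ccco3)c2)cc1` differs from compound 3 by furan-2-yl in place of pyridin-4-yl on an aromatic carbon; the group that leaves is pyridin-4-yl and the one that enters is furan-2-yl, the change sitting next to the ring nitrogen of the core. Within the data shown here, no measured pair shows this exact exchange, so the size of the step in this assay cannot be read from a neighbour; it is expected, on balance, to leave compound 4 nearer the stronger end seen for compound 1 than the weaker end seen for compound 2.

Compound 4 is therefore estimated at 3000 nM in this assay, with a likely range from 800 nM to 12000 nM.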

Compound 4, half-maximal inhibitory concentration: 5750 nM
Estimate against measurement, compound 4: 1.9-fold (0.28 log units) below; the range from low to high includes it.
By their numbers in this assay, from the lowest: compound 1; then compound 4; then compound 2.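

In this assay the position next to the ring nitrogen now has a readable exchange: furan-2-yl in place of pyridin-3-yl gives a 4.0-fold lower number from compound 2 to compound 4 (0.60 log units; beyond the scatter) and so shows that the group at this position can change the result beyond the usual scatter. Among these compounds, a second exchange, elsewhere on the core, shows what the earlier compounds could not: 4-hydroxyphenyl in place of 3-hydroxyphenyl gives a 2.8-fold higher number from compound 1 to compound 4 (0.45 log units; beyond the scatter) while furan-2-yl stays in place. Nothing available explains either step.

The step from compound 3 cannot be read, so pyridin-4-yl remains uncompared with furan-2-yl. The compounds shown also leave open how a non-aromatic group at the furan-2-yl position, such as an amine or a carboxylic acid, would behave.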